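Swapping chloro for hydrogen on compound 2

A few compounds are considered here, and "the series" means these few. Any claim that something is new, unique, unknown or untested is made for them only; others in the source may bear on it.

Measured so far in a functional assay on A549 cells (Homo sapiens) for antiproliferative activity, read by MTT assay, with a stated time of 72 h (on this read-out lower numbers stand for stronger inhibition and higher numbers for weaker inhibition), are two compounds:
Compound 1 `COc1ccc(N2C(=O)COc3ccc(-c4cnc(Cl)c(NS(=O)(=O)c5ccc(F)cc5)c4)cc32)cc1` gives 30400 nM here
Compound 2 `O=C1COc2ccc(-c3cnc(Cl)c(NS(=O)(=O)c4ccc(F)cc4)c3)cc2N1c1ccc(Cl)cc1` gives 21600 nM here

Compound 2 at 21600 nM stands within the scatter of compound 1 and holds no clear place of its own. Compound 3 `O=C1COc2ccc(-c3cnc(Cl)c(NS(=O)(=O)c4ccc(F)cc4)c3)cc2N1c1ccccc1` differs from compound 2 at one place (hydrogen in place of chloro on an aromatic carbon) with hydrogen in place of chloro on an aromatic carbon. For the measured compounds named here, the only measured step bearing on this is a 1.4-fold lower number from compound 1 to compound 2 (0.15 log units; within the scatter) for chloro in place of methoxy at that same carbon. Going by the values given here, no measured compound carries hydrogen there. No step beyond the scatter is therefore expected in this assay for this change. The expected step is a 1.2-fold higher number from compound 2 to compound 3 (0.06 log units; within the scatter) by estimate. Compound 3 is estimated at 25000 nM with an expected range from 12000 nM to 50000 nM as its likely span.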

Compound 3, half-maximal inhibitory concentration: 14700 nM
The estimate for compound 3 lay 1.7-fold (0.23 log units) above the measured number; the range from low to high includes it.
By their numbers in this assay, from the lowest: compounds 3, 2 and 1 (each within the scatter of the next, the first and the last beyond it).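

In this assay, for the compounds shown here, the 4-chlorophenyl to phenyl change gives no step that can be told from the scatter (a 1.5-fold lower number from compound 2 to compound 3 (0.17 log units; within the scatter)), so chloro and hydrogen are not separated on this aromatic carbon. Hydrogen in place of methoxy gives the first step at this carbon beyond the scatter, though only a modest one (a 2.1-fold lower number from compound 1 to compound 3 (0.32 log units; beyond the scatter)). No evidence here accounts for either step.

From the compounds shown here alone, whether an amine, a carboxylic acid or a fluoro group on this carbon would give a step beyond the scatter from compound 3 remains open. So does what changes elsewhere on the shared core would do.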